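Cytotoxicity in HeLa cells: a nitro for a fluoro

A few compounds are considered here, and "the series" means these few. Any claim that something is new, unique, unknown or untested is made for them only; others in the source may bear on it.

Compound 1, `COc1cc(CC(O)c2ccc(-c3cccc(C#N)c3)cc2)c([N+](=O)[O-])cc1OC`: 5200 nM
Compound 2, `COc1cc(CC(O)c2ccc(-c3cccc([N+](=O)[O-])c3)cc2)c([N+](=O)[O-])cc1OC`: 5500 nM
Compound 3, `COc1cc(CC(O)c2ccc(-c3ccccc3F)cc2)c([N+](=O)[O-])cc1OC`: 5000 nM

Of the compounds shown here, three sharing one core have been tested in an ADME assay on HeLa Rh cells (Homo sapiens) for cytotoxicity, read by microscopy; a lower number here means that less compound is tolerated, a higher number that more compound is tolerated. Compound 1 gives 5200 nM, compound 2 gives 5500 nM, and compound 3 gives 5000 nM. The steps between them are small: a 1.1-fold higher number from compound 1 to compound 2 (0.02 log units; within the scatter), a 1.0-fold lower number from compound 1 to compound 3 (0.02 log units; within the scatter) and a 1.1-fold lower number from compound 2 to compound 3 (0.04 log units; within the scatter). Compound 3 therefore stands within the scatter of both others, and none of the three can be set apart.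

Compound 4, `COc1cc(CC(O)c2ccc(-c3ccccc3[N+](=O)[O-])cc2)c([N+](=O)[O-])cc1OC`, has not yet been measured in this assay. It differs from compound 3 in one place: nitro in place of fluoro on an aromatic carbon. The step that bears most directly on it is the one in which a nitro replaced a cyano on an aromatic carbon, a 1.1-fold higher number from compound 1 to compound 2 (0.02 log units; within the scatter), which stayed within the scatter; the steps to compound 3 from compounds 1 and 2, which exchanged whole substituted phenyl groups, likewise moved nothing beyond the scatter. From this the account expects no change beyond the scatter in this assay, with compound 4 expected to sit at a 1.1-fold higher number from compound 3 to compound 4 (0.03 log units; within the scatter) from compound 3. Compound 4 is thus estimated at 5300 nM, with a range from 2600 nM to 10600 nM.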

Compound 4, half-maximal cytotoxic concentration: 9500 nM
Beside the measured number, compound 4's estimate is 1.8-fold (0.25 log units) below it; low and high end bracket the measured number.
By their numbers in this assay, from the lowest: compounds 3, 1, 2 and 4 (each within the scatter of the next).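

In this assay, the exchange on an aromatic carbon ortho to a large group puts a nitro where a fluoro stood, which adds heavy atoms and two hydrogen-bond acceptors, and the result is a 1.9-fold higher number from compound 3 to compound 4 (0.28 log units; within the scatter). The other two exchanges of a whole substituted phenyl group read the same way: 2-nitrophenyl in place of 3-nitrophenyl gives a 1.7-fold higher number from compound 2 to compound 4 (0.24 log units; within the scatter), and 2-nitrophenyl in place of 3-cyanophenyl gives a 1.8-fold higher number from compound 1 to compound 4 (0.26 log units; within the scatter), so this position now accepts the larger nitro as well as fluoro without any of the four compounds being set apart. No measurement at hand bears on why the numbers fall as they do.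

As far as these compounds go, whether an amine, a carboxylic acid or a longer chain on this aromatic carbon would move the number beyond the scatter remains open. The rest of the shared core is the same in all four compounds, so they also say nothing about what a change there would do to the tolerated concentration.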